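Ester in place of amide on the shared anilino substituent

The source may hold more compounds than are shown below. What is called first, only, known or untested is meant among the compounds shown, and "the series" means these compounds.

Measured so far:
Compound 1 `O=C1C(Nc2ccc(-c3ccc(F)cc3)cc2)=CC(=O)c2ncncc21` gives 3500 nM in a functional assay on MIA PaCa-2 cells (Homo sapiens) for cytotoxicity, read by MTT assay, with a stated time of 72 h; a lower number here means a stronger inhibitor, a higher number a weaker inhibitor.
Compound 2 `NC(=O)c1ccc(NC2=CC(=O)c3ncncc3C2=O)cc1` gives 8000 nM in this assay.

For the measured compounds named here, compound 2 holds the higher of the two numbers; the only neighbour is compound 1, and the change a 2.3-fold higher number from compound 1 to compound 2 (0.36 log units; beyond the scatter) made it the weaker of the pair. Compound 3 `CCOC(=O)c1ccc(NC2=CC(=O)c3ncncc3C2=O)cc1` has not been measured. It differs from compound 2 in one place: ethoxy in place of amino on a carbonyl carbon. Going by the values given here, no measured step reproduces this amide-to-ester exchange; the single known step at this end of the molecule, a 2.3-fold higher number from compound 1 to compound 2 (0.36 log units; beyond the scatter), only shows that a different group there shifts the number modestly. With nothing closer to lean on, the expectation is a step of a 1.3-fold lower number from compound 2 to compound 3 (0.12 log units; within the scatter), no larger than the ordinary spread of repeats, in either direction. Compound 3 is therefore estimated at 6000 nM, within a range of 2500 nM to 15000 nM.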

Compound 3, half-maximal inhibitory concentration: 5500 nM
The estimate for compound 3 lay 1.1-fold (0.04 log units) above the measured number; the measured number falls inside the stated range.
By their numbers in this assay, from the lowest: compounds 1, 3 and 2 (each within the scatter of the next, the first and the last beyond it).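

In this assay, the exchange of carbamoyl for ethoxycarbonyl gives a small step (a 1.5-fold lower number from compound 2 to compound 3 (0.16 log units; within the scatter)), so the amino group on this carbonyl carbon, with the hydrogen-bond donor it carries, can give way to ethoxy without a change that stands out from repeat measurements. Compound 3 also cannot be told apart from the 4-fluorophenyl compound (a 1.6-fold higher number from compound 1 to compound 3 (0.20 log units; within the scatter)), so it lies within the scatter of both neighbours, even though those two neighbours differ from each other by more than the scatter. Nothing measured here accounts for these similar numbers.

As far as these compounds go, it remains open how a carboxylic acid, a methyl ester or a longer alkoxy chain in place of ethoxy on this carbonyl carbon would read. From the compounds shown here alone, it is also open whether any such group would move the number clearly beyond the scatter.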